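The compounds below may be only part of what the source reports. "The series", "measured", "known", "first", "only" and "open" are said of these compounds alone.

Measured compounds:
compound 1 `Cc1occc1-c1nnc2sc(-c3ccnc(F)c3)nn12` — 18.2%
compound 2 `COc1ccc2[nH]cc(Cc3nn4c(Cc5ccc(OC)c(OC)c5)nnc4s3)c2c1` — 11.6%

In a functional assay on the whole organism (strain Wistar Albino) for inhibition, with Rattus norvegicus as the target, read by paw edema, with a stated time of 2 h, at a dose of 20 mg/kg (on this read-out higher numbers stand for more inhibition at the one dose given (going by the name of the read-out) and lower numbers for less inhibition), compound 1 gives 18.2% and compound 2 gives 11.6%. Compound 2 and compound 1 lie within the scatter of each other, so the two numbers show no difference that can be read. Compound 3 `COc1ccc2[nH]c(C)c(Cc3nn4c(Cc5ccc(OC)c(OC)c5)nnc4s3)c2c1` is not yet measured. It differs from compound 2 by methyl in place of hydrogen on an aromatic carbon. For the measured compounds named here, no step between measured compounds in this assay is available, so the size of this change is unknown; a step of no more than the scatter, in either direction, is expected. Compound 3 is estimated at 12% in this assay, in the range 4% to 24%, which is expected to mean a step of a number 0.4 percentage points higher from compound 2 to compound 3 (within the scatter).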

Compound 3, a percentage reported as inhibition, in the whole organism at one dose (the size of the read-out at that dose, not a potency): 16.2%
For compound 3 the middle estimate is 4.2 percentage points below the measured one; the measured number falls inside the stated range.
By their numbers in this assay, from the lowest: compounds 2, 3 and 1 (each within the scatter of the next).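

In this assay, methyl in place of hydrogen on the aromatic carbon gives a number 4.6 percentage points higher from compound 2 to compound 3 (within the scatter), the first step measured in this series. At this place, next to the ring nitrogen and next to the ring atom that bears a large group, the added methyl produces no readable change in inhibition. No measured evidence bears on this result.

Open, going by these compounds, is whether a larger or different group at this carbon, such as an amine, a carboxylic acid or a longer chain, would move the number beyond the scatter. Also open, on these data alone, is whether methyl behaves the same way on other cores.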